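Epoxide Versus Open Alcohol in a Weakly Cytotoxic Series

The compounds below may be only part of what the source reports. "The series", "measured", "known", "first", "only" and "open" are said of these compounds alone.

The measured compounds:
Compound 1 `C=CC(=C)CC[C@@H]1[C@@]2(C)CCC[C@](C)(COC(=O)/C=C\c3ccc(O)cc3)[C@@H]2CC[C@@]1(C)O` gives 14100 nM in a functional assay on HL-60 cells (Homo sapiens) for cytotoxicity, read by MTT assay, with a stated time of 48 h; on this read-out higher numbers stand for weaker inhibition and lower numbers for stronger inhibition.
Compound 2 `C=C1CC[C@@H]2[C@](C)(CCC[C@]2(C)C(=O)O)[C@H]1CC/C(C)=C/CO` gives > 40000 nM in this assay, and this figure is a limit of the assay rather than a number.
Compound 3 `C=C[C@@]1(C)O[C@H]1C[C@H]1C(=C)CC[C@@H]2[C@]1(C)CCC[C@]2(C)C(=O)O` gives > 40000 nM in this assay, again only a limit.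

Compound 3 therefore stands at the edge of what this assay can report: the limit of > 40000 nM in this assay, at which 2 of the 3 values shown sit. Among the compounds with values here, the only measured step that touches its side chain is a step that the two limits leave unreadable from compound 2 to compound 3, and with both ends sitting at limits its size cannot be read, so no measured step gives a usable guide.

Compound 4 `C=CC(=C)[C@H](O)C[C@H]1C(=C)CC[C@@H]2[C@]1(C)CCC[C@]2(C)C(=O)O` carries the same atoms as compound 3 joined differently: a group of 6 heavy atoms (5 carbon, 1 oxygen; no ring) in place of a group of 6 heavy atoms (5 carbon, 1 oxygen; one three-membered non-aromatic ring with 1 hetero atom), on a saturated chain carbon bound to a saturated ring carbon. Within the data shown here, with compound 3 at a limit and the one related step unreadable, compound 4 is expected to stay near the same region, most likely again reported only as a limit. The step from compound 3 is estimated as a number no higher from compound 3 to compound 4 (the limit leaves the size open). Compound 4 is expected to give about 40000 nM, within a range from 15000 nM to 100000 nM.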

Compound 4, half-maximal inhibitory concentration: > 40000 nM
Compound 4: only a limit was reported; the forecaster's own chance of this, stated with the estimate: 60%; the middle value sits exactly at the limit.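

Compound 2, compound 3 and compound 4 are all reported only as limits, so no step among them can be read: the limit of > 40000 nM in this assay, at which 3 of the 4 values shown sit.

From the compounds shown here alone, whether these three compounds differ at all in this assay, and how their side chains would rank, stays open.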